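The source may hold more compounds than are shown below. What is called first, only, known or untested is meant among the compounds shown, and "the series" means these compounds.

Measured in a functional assay on RS4-11 cells (Homo sapiens) for inhibition, read by CCK-8 assay, with a stated time of 72 h; a lower number here means a stronger inhibitor, a higher number a weaker inhibitor:
- compound 1 `CC1(C)CCC(CN2CCN(c3ccc(C(=O)NS(=O)(=O)c4ccc(NC5CCOC5)c([N+](=O)[O-])c4)c(Oc4cnc5[nH]ccc5c4)c3)CC2)=C(c2ccc(C(F)(F)F)cc2)C1`: 32 nM
- compound 2 `CC1(C)CCC(CN2CCN(c3ccc(C(=O)NS(=O)(=O)c4ccc(OCC5CCOCC5)c([N+](=O)[O-])c4)c(Oc4cnc5[nH]ccc5c4)c3)CC2)=C(c2ccc(C(F)(F)F)cc2)C1`: 5.9 nM

Compound 2, at 5.9 nM, holds the lower of the two numbers, and compound 1 sits at 32 nM. Compound 3 `CC(Oc1ccc(S(=O)(=O)NC(=O)c2ccc(N3CCN(CC4=C(c5ccc(C(F)(F)F)cc5)CC(C)(C)CC4)CC3)cc2Oc2cnc3[nH]ccc3c2)cc1[N+](=O)[O-])C1CCOCC1` is still to be measured. It differs from compound 2 by methyl in place of hydrogen on a saturated chain carbon bound to an oxygen on an aromatic ring and a saturated ring carbon. The same difference reads (oxan-4-yl)methyl to 1-(oxan-4-yl)ethyl.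

Going by the values given here, only one measured step bears on this: a 5.4-fold lower number from compound 1 to compound 2 (0.73 log units; beyond the scatter). It replaces (oxolan-3-yl)amino with (oxan-4-yl)methoxy, a far larger exchange than the one here. Among the compounds with values here, it shows that the number can move with changes to this substituent, but no measured step adds a methyl, so the size of the present step is not established. Within the data shown here, a small step is expected, with no firm direction and a slight allowance upward from the lower of only two values.

The estimated step is a 1.2-fold higher number from compound 2 to compound 3 (0.07 log units; within the scatter), which is not expected to exceed the scatter. The expected value for compound 3 is 7 nM, with an estimated range of 2.5 nM to 20 nM.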

Compound 3, half-maximal inhibitory concentration: 269 nM
Estimate against measurement, compound 3: 38-fold (1.58 log units) below; measured number above the stated range.
By their numbers in this assay, from the lowest: compound 2; then compound 1; then compound 3.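

In this assay, a methyl in place of hydrogen on a saturated chain carbon bound to an oxygen on an aromatic ring and a saturated ring carbon gives a 46-fold higher number from compound 2 to compound 3 (1.66 log units; beyond the scatter) as a large step for only 1 carbon added, a sensitivity that the earlier exchange of whole substituents could not isolate. The order among the substituents changes as well: a 5.4-fold lower number from compound 1 to compound 2 (0.73 log units; beyond the scatter) stands against an 8.4-fold higher number from compound 1 to compound 3 (0.92 log units; beyond the scatter) with the 1-(oxan-4-yl)ethyl group in place, so the gain seen with (oxan-4-yl)methoxy is lost entirely once this carbon carries the methyl. Nothing at hand accounts for this loss.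

The compounds shown leave open whether an ethyl, a hydroxymethyl or a second methyl on the same carbon would move the number further in the same direction or whether the loss is particular to a single methyl. Also open, as far as these compounds go, is whether the two mirror-image forms of compound 3 would give the same number in this assay or would differ from each other.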